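The source may hold more compounds than are shown below. What is called first, only, known or untested is meant among the compounds shown, and "the series" means these compounds.

Measured set:
compound 1 `O=C1OC(c2cc(O)cc(O)c2)C(c2ccc(O)cc2)=C1O` gives 0%
compound 2 `O=C1OC(c2ccc(O)c(O)c2)C(c2ccc(O)cc2)=C1O` gives 35.4%
compound 3 `O=C1OC(c2ccc(O)cc2)C(c2ccc(F)cc2)=C1O` gives 0%

All three were run in an assay on blood for inhibition of Polyunsaturated fatty acid 5-lipoxygenase (Homo sapiens), tested at 10 uM; a higher number here means a stronger effect of the compound at the concentration tested, a lower number a weaker effect. Compound 1 stands level with compound 3 at the digits reported, and together they are the lowest of the three numbers; the gap between compound 1 and compound 3 lies within the scatter, so no order can be read between them. Among the measured compounds shown here, compound 2 lies higher than compound 1 by an amount that is beyond the scatter; no single-point step between any two measured compounds is available, so that gap is taken only as what the two values show.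

The unmeasured compound 4 `O=C1OC(c2cc(O)cc(O)c2)C(c2ccc(F)cc2)=C1O` is reached from compound 1 by one change: fluoro in place of hydroxy on an aromatic carbon. The same fluoro on the same ring is already present in compound 3, which sits at the same low level as compound 1 in this assay. With compound 1 at the floor of the read-out and compound 3 giving no sign that the fluorophenyl ring lifts activity, the step from compound 1 to compound 4 in this assay is expected to be none beyond the scatter, and the estimate is a number 3 percentage points higher from compound 1 to compound 4 (within the scatter). Compound 4 is therefore expected to give 3%, within a range of 0% to 15%.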

Compound 4, a percentage reported as activity, at one concentration (the size of the read-out at that concentration, not a potency): 0%
Estimate against measurement, compound 4: 3 percentage points above; the measured number falls inside the stated range.
By their numbers in this assay, from the lowest: compounds 1, 3 and 4 (each within the scatter of the next); then compound 2.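

In this assay, among the compounds shown here, the only single-place step reads no change at the digits printed from compound 1 to compound 4 (within the scatter): with fluoro in place of hydroxy on this aromatic carbon, para to a large group, the number does not move on the core of compound 1. For the compounds shown here, until now, no pair isolated this position, so this is the first direct reading of the 4-hydroxyphenyl to 4-fluorophenyl change, and it shows that the hydroxy here is not enough on its own to give a measurable effect at the concentration tested on this core. With both ends of the step at the bottom of the read-out, it cannot show whether the hydroxy contributes anything at all, and no data at hand bear on why the step reads this way.

On these data alone, compound 2 gives 35.4%, so it remains open whether the same change would alter the number on a compound that stands clear of the bottom of the read-out. As far as these compounds go, it is also open whether an amine, a methoxy group or a carboxylic acid at this position would lift the number on the core of compound 1.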